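Dechlorination in a chromone series: a step with two scaffolds

The compounds below may be only part of what the source reports. "The series", "measured", "known", "first", "only" and "open" are said of these compounds alone.

Compound 1 `O=c1c(C(=S)Nc2ccccc2)coc2cc(Cl)ccc12` and compound 2 `O=c1c(C2N=C(c3ccccc3)SS2)coc2ccc(Cl)cc12` share a chlorinated chromone core but carry different side groups at the same position; the difference between the two cores is not broken down here. In a functional assay on OVCAR-3 cells (Homo sapiens) for inhibition, read by sulforhodamine B assay, with a stated time of 48 h (on this read-out higher numbers stand for weaker inhibition and lower numbers for stronger inhibition), compound 1 gives a limit of > 100000 nM. Compound 2 gives 66500 nM in this assay. Compound 3 `O=c1c(C2N=C(c3ccccc3)SS2)coc2ccccc12` gives a limit of > 100000 nM in this assay. The change from compound 2 to compound 3 is hydrogen in place of chloro on an aromatic carbon, and it made an at least 1.5-fold higher number from compound 2 to compound 3 (0.17 log units; that floor lies within the scatter); this reading is bounded by the limit of > 100000 nM in this assay, at which 2 of the 3 values shown sit.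

Compound 4 `O=c1c(C(=S)Nc2ccccc2)coc2ccccc12` is not yet measured. Its change from compound 1 is hydrogen in place of chloro on an aromatic carbon, the same change as from compound 2 to compound 3. Compound 1 already sits at the limit of the limit of > 100000 nM in this assay, at which 2 of the 3 values shown sit, and the one measured case of this change went toward weaker inhibition, so compound 4 is expected to remain at or past that limit, with an estimated step that the limit leaves unreadable from compound 1 to compound 4. Compound 4 is estimated at 200000 nM, in a range from 100000 nM to 500000 nM.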

Compound 4, half-maximal inhibitory concentration: 86400 nM
Beside the measured number, compound 4's estimate is 2.3-fold (0.36 log units) above it; measured number outside the range, below it.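

Replacing chloro by hydrogen on the core of compound 1 gives, in this assay, an at least 1.1-fold lower number from compound 1 to compound 4 (0.06 log units; that floor lies within the scatter), and this floor rests on a limit and not on a number. Set beside the same replacement on the other core, this step shows neither that the change carries over from one core to the other nor that it fails to: the same change on two cores in this assay, an at least 1.5-fold higher number (0.17 log units; that floor lies within the scatter) from compound 2 to compound 3 and an at least 1.1-fold lower number (0.06 log units; that floor lies within the scatter) from compound 1 to compound 4; the limit leaves it open whether they differ. Neither step has a readable size, and the direction of the change on either core stays unsettled, because the limit touches both pairs: the limit of > 100000 nM in this assay, at which 2 of the 4 values shown sit.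

Going by these compounds, whether another group on that aromatic carbon, such as fluoro, methoxy or an amine, would bring the values clear of the limit and of the usual scatter remains open. Also open, on these data alone, is how the change from chloro to hydrogen would read on a core where both partners of the pair give numbers rather than a limit.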